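This account rests on a few compounds, and the source may have more. Where it says the series, first, only, none or still open, it means among the compounds named here.

Working notes on the series. Compound 1 `O=C(CCCCC#Cc1ccccn1)c1ncc(-c2ccccn2)o1` gives 280 nM in an assay for inhibition of Fatty-acid amide hydrolase 1 (Rattus norvegicus); on this read-out lower numbers stand for stronger inhibition and higher numbers for weaker inhibition. Among the compounds with values here, compound 2 `O=C(CCCCC#Cc1ccc(Cl)cc1)c1ncc(-c2ccccn2)o1` gives 20 nM in this assay; the single recorded step, a 14-fold lower number from compound 1 to compound 2 (1.15 log units; beyond the scatter), came with 4-chlorophenyl in place of pyridin-2-yl on a triple-bonded carbon. Within the data shown here, compound 2 therefore holds the lowest of the two numbers, with compound 1 the only neighbour, standing well beyond the scatter from it.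

Compound 3 `O=C(CCCCC#Cc1cccc(Cl)c1Cl)c1ncc(-c2ccccn2)o1` is the next member and is not yet measured. The change it brings is 2,3-dichlorophenyl in place of 4-chlorophenyl on a triple-bonded carbon. Among the measured compounds shown here, the only measured step that bears on this position is the one from compound 1 to compound 2, and it was large, but it exchanged a pyridin-2-yl for a chlorinated phenyl; nothing recorded so far compares one chlorinated phenyl with another at this place. The expectation is thus a step no larger than the scatter, in either direction, leaning towards a number close to that of compound 2. Compound 3 is expected to give about 25 nM in this assay, within 8 nM to 80 nM, that is an estimated step of a 1.3-fold higher number from compound 2 to compound 3 (0.10 log units; within the scatter).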

Compound 3, inhibition constant: 5 nM
For compound 3 the middle estimate is 5.0-fold (0.70 log units) above the measured one, and the stated range ends above it.
By their numbers in this assay, from the lowest: compound 3; then compound 2; then compound 1.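

The position on the triple-bonded carbon responds not only to the exchange of pyridin-2-yl for a chlorinated phenyl, but also to a change from one chlorinated phenyl to another: 2,3-dichlorophenyl in place of 4-chlorophenyl gives a 4.0-fold lower number from compound 2 to compound 3 (0.60 log units; beyond the scatter) in this assay, a modest step but one that a single chlorinated phenyl at this place could not have shown. Measured against pyridin-2-yl, the same group gives a 56-fold lower number from compound 1 to compound 3 (1.75 log units; beyond the scatter), which is larger than the step recorded for 4-chlorophenyl and leaves compound 3 with the lowest number of the three compounds. No measurement is at hand that explains either step.

The step from 4-chlorophenyl to 2,3-dichlorophenyl alters both the count of chlorine atoms and where they stand on the phenyl ring, and the compounds shown do not separate these two changes. As far as these compounds go, it also remains open how other groups on that ring, such as a trifluoromethyl or a methoxy group, would compare with chlorine, and whether a longer chain would preserve the low number of compound 3.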